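Methoxy additions and cytotoxicity in a shared-core series

The source may hold more compounds than are shown below. What is called first, only, known or untested is meant among the compounds shown, and "the series" means these compounds.

Measured so far in a functional assay on HepG2 cells (Homo sapiens) for cytotoxicity, read by MTT assay, with a stated time of 48 h; on this read-out lower numbers stand for stronger inhibition and higher numbers for weaker inhibition:
Compound 1 `CNC(=O)CSc1nc2ccc(NC(=O)c3ccccc3OC)cc2s1` gives 18500 nM.
Compound 2 `CNC(=O)CSc1nc2ccc(NC(=O)c3ccccc3)cc2s1` gives 26500 nM.
Compound 3 `O=C(CSc1nc2ccc(NC(=O)c3ccc([N+](=O)[O-])cc3)cc2s1)NCc1ccccc1` gives > 100000 nM, which is a limit of the assay and not a number.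

Compound 2 and compound 1 differ by methoxy in place of hydrogen on an aromatic carbon; the step is a 1.4-fold lower number from compound 2 to compound 1 (0.16 log units; within the scatter). Compound 3 differs from compound 2 in its amide end, and the difference between the two cores is not broken down here.

Compound 4 `COc1ccc(CNC(=O)CSc2nc3ccc(NC(=O)c4ccc([N+](=O)[O-])cc4)cc3s2)cc1` is not yet measured. It differs from compound 3 by methoxy in place of hydrogen on an aromatic carbon. This is the same kind of change as from compound 2 to compound 1, not the same: the place is ortho to a large group in the first case and para to a large group in the second, phenyl to 2-methoxyphenyl versus benzyl to 4-methoxybenzyl.

The expected step is a number no higher from compound 3 to compound 4 (the limit leaves the size open), since the measured step was a 1.4-fold lower number from compound 2 to compound 1 (0.16 log units; within the scatter) and compound 3 sits at the limit of > 100000 nM in this assay, at which 1 of the 3 values shown sits. Compound 4 is estimated at 100000 nM, between 40000 nM and 250000 nM, and is expected most likely to be reported as a limit again.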

Compound 4, half-maximal inhibitory concentration: > 100000 nM
Compound 4 ended at the assay's limit; the forecaster's own chance of this, stated with the estimate: 65%; the middle value sits exactly at the limit.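

Compound 3 and compound 4 both end at a limit and not at a number, so the step between them cannot be read: the limit of > 100000 nM in this assay, at which 2 of the 4 values shown sit.

The compounds shown leave open whether benzyl to 4-methoxybenzyl changes the read-out at all.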